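A few compounds are considered here, and "the series" means these few. Any claim that something is new, unique, unknown or untested is made for them only; others in the source may bear on it.

Measured in a physicochemical assay for lipophilicity; on this read-out lower numbers stand for lower lipophilicity and higher numbers for higher lipophilicity:
- compound 1 `C#CCNC(=O)C[C@H](NC(=O)c1ccc(C#Cc2ccccc2)cc1)C(=O)NO`: 3
- compound 2 `COCCNC(=O)C[C@H](NC(=O)c1ccc(C#Cc2ccccc2)cc1)C(=O)NO`: 2
- compound 3 `O=C(C[C@H](NC(=O)c1ccc(C#Cc2ccccc2)cc1)C(=O)NO)NCCCO`: 2

Compound 3 sits level with compound 2 at the digits shown, the two together the lowest of the three (no change at the digits printed from compound 2 to compound 3 (within the scatter)), and below compound 1 (a number 1.00 log units lower from compound 1 to compound 3 (beyond the scatter)).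

Compound 4 `CS(=O)(=O)C[C@H](NC(=O)c1ccc(C#Cc2ccccc2)cc1)C(=O)NO` is not yet measured in this assay. It differs from compound 3 by methylsulfonyl in place of (3-hydroxypropyl)carbamoyl on a saturated chain carbon, two bonds along the chain from an amide-type nitrogen and a carbonyl carbon. For the measured compounds named here, no measured step covers this exchange. The steps of a number 1.00 log units lower from compound 1 to compound 2 (beyond the scatter) and a number 1.00 log units lower from compound 1 to compound 3 (beyond the scatter) replace ethynyl and are modest; the step of no change at the digits printed from compound 2 to compound 3 (within the scatter) swaps one chain end for another with no change. On that basis a step of about a number 0.20 log units lower from compound 3 to compound 4 (within the scatter) is expected, within the scatter, possibly slightly lower. Compound 4 is estimated at 1.8, range 1.2 to 2.5.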

Compound 4, distribution coefficient: 2
For compound 4 the middle estimate is 0.20 log units below the measured one; measured number inside the range.
By their numbers in this assay, from the lowest: compounds 2, 3 and 4 (each within the scatter of the next); then compound 1.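

In this assay methylsulfonyl in place of (3-hydroxypropyl)carbamoyl gives no change at the digits printed from compound 3 to compound 4 (within the scatter) and methylsulfonyl in place of (2-methoxyethyl)carbamoyl gives no change at the digits printed from compound 2 to compound 4 (within the scatter) so at this position the whole carbamoyl group can be exchanged, not only the chain end. Methylsulfonyl in place of propargylcarbamoyl gives a number 1.00 log units lower from compound 1 to compound 4 (beyond the scatter) so compound 1 still stands apart from the other three. Nothing available bears on the cause of these readings.

Open, going by these compounds, is how a carboxylic acid or an amine at this position would read in this assay. On these data alone, a longer chain on the sulfonyl group also remains open.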